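A ureido group replaces (1,3-thiazol-2-yl)amino

The source may report more compounds than this note shows. Statements on the series, on what has been measured and on what is new or still open speak of the compounds shown alone.

Of the compounds shown here, three sharing one core have been measured in a functional assay on G-361 cells (Homo sapiens) for cytotoxicity, read by MTT assay, with a stated time of 3 days; on this read-out higher numbers stand for weaker inhibition and lower numbers for stronger inhibition. There, compound 1 `N#Cc1c(O)nc(SCc2nc3ccccc3[nH]2)nc1-c1ccccc1` gives 3.43 nM, compound 2 `N#Cc1c(Nc2ccccn2)nc(SCc2nc3ccccc3[nH]2)nc1-c1ccccc1` gives 8.9 nM and compound 3 `N#Cc1c(Nc2nccs2)nc(SCc2nc3ccccc3[nH]2)nc1-c1ccccc1` gives 11.9 nM. Compound 3 thus stands with compound 2 in the upper part of this small range: the measured steps are a 1.3-fold higher number from compound 2 to compound 3 (0.13 log units; within the scatter) and a 3.5-fold higher number from compound 1 to compound 3 (0.54 log units; beyond the scatter).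

Compound 4 `N#Cc1c(NC(N)=O)nc(SCc2nc3ccccc3[nH]2)nc1-c1ccccc1` keeps the shared core and carries a different group on the nitrogen, the change being (carbamoyl in place of 1,3-thiazol-2-yl on a nitrogen on an aromatic ring). This turns (1,3-thiazol-2-yl)amino into ureido. Going by the values given here, no ureido compound has been measured yet, so the guidance is indirect. Exchanging the group on this nitrogen gave only a 1.3-fold higher number from compound 2 to compound 3 (0.13 log units; within the scatter), and replacing hydroxy gave the modest 2.6-fold higher number from compound 1 to compound 2 (0.41 log units; beyond the scatter) and a 3.5-fold higher number from compound 1 to compound 3 (0.54 log units; beyond the scatter). On these steps, no large shift is expected, and probably none beyond the scatter, though the range must stay wide. The expected step is a 1.3-fold lower number from compound 3 to compound 4 (0.12 log units; within the scatter). Compound 4 is estimated at 9 nM, with an expected range of 3 nM to 30 nM.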

Compound 4, half-maximal inhibitory concentration: 2.55 nM
The estimate for compound 4 lay 3.5-fold (0.55 log units) above the measured number, outside the stated range (below it).
By their numbers in this assay, from the lowest: compounds 4 and 1 (each within the scatter of the next); then compounds 2 and 3 (each within the scatter of the next).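

In this assay, the group on this nitrogen matters more than the exchange of pyridin-2-yl for 1,3-thiazol-2-yl had shown: carbamoyl in place of 1,3-thiazol-2-yl gives a 4.7-fold lower number from compound 3 to compound 4 (0.67 log units; beyond the scatter), and carbamoyl in place of pyridin-2-yl gives a 3.5-fold lower number from compound 2 to compound 4 (0.54 log units; beyond the scatter). Ureido and hydroxy on this aromatic carbon cannot be told apart, with a 1.3-fold lower number from compound 1 to compound 4 (0.13 log units; within the scatter), so among these four compounds the two with an aromatic ring on the nitrogen give the higher numbers. No measurement available here explains this difference.

From the compounds shown here alone, it remains open whether the carbamoyl group needs its terminal amine, which an acetyl group on the same nitrogen would test. Going by these compounds, how a plain amino group or a methylcarbamoyl group on this position would compare also remains open.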